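Sulfonamide N-methylation on a TRPV1 antagonist scaffold

This account rests on a few compounds, and the source may have more. Where it says the series, first, only, none or still open, it means among the compounds named here.

Measured compounds:
Compound 1, `CC1CCN(c2nc(C(F)(F)F)ccc2CNC(=O)C(C)c2ccc(NS(C)(=O)=O)c(Cl)c2)CC1`, 2.3 nM
Compound 2, `CCS(=O)(=O)Nc1ccc(C(C)C(=O)NCc2ccc(C(F)(F)F)nc2N2CCC(C)CC2)cc1F`, 4.4 nM

In an assay on cells for antagonist activity at transient receptor potential cation channel subfamily V member 1 (Homo sapiens), read by FLIPR and calcium flux, with a stated time of 15 min (a lower number here means a stronger inhibitor, a higher number a weaker inhibitor), compound 2 gives 4.4 nM, the higher of the two numbers, while compound 1 gives 2.3 nM, a gap within the scatter. Compound 3, `CC1CCN(c2nc(C(F)(F)F)ccc2CNC(=O)C(C)c2ccc(N(C)S(C)(=O)=O)c(F)c2)CC1`, is not yet measured; it carries methyl(methylsulfonyl)amino in place of (ethylsulfonyl)amino on an aromatic carbon. Among the compounds with values here, no measured pair shows this change, so the data offer no step to lean on. Compound 3 is expected to lose potency, by a 6.8-fold higher number from compound 2 to compound 3 (0.83 log units; beyond the scatter), beyond the scatter. The estimate for compound 3 in this assay is 30 nM, in the range 6 nM to 150 nM.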

Compound 3, inhibition constant: 55.5 nM
Estimate against measurement, compound 3: 1.9-fold (0.27 log units) below; the measured number falls inside the stated range.
By their numbers in this assay, from the lowest: compounds 1 and 2 (each within the scatter of the next); then compound 3.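

In this assay, within the data shown here, the change of (ethylsulfonyl)amino to methyl(methylsulfonyl)amino gives the first step at this position, a 13-fold higher number from compound 2 to compound 3 (1.10 log units; beyond the scatter), a large loss of potency. The entering group has the same heavy-atom count as the leaving one but no hydrogen-bond donor, so this position, ortho to a fluoro group, does not tolerate every group of that size. Nothing measured here accounts for the loss.

The compounds shown leave open whether the loss follows the methyl on the nitrogen or the shortened sulfonyl chain, as both change in this one step. As far as these compounds go, how an ethyl group on that nitrogen, or a carboxylic acid at this position, would read also remains open.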